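Swapping the sulfonyl aryl group in a sulfonamide series

This account rests on a few compounds, and the source may have more. Where it says the series, first, only, none or still open, it means among the compounds named here.

The series shares one core, seen in compound 1 `CCN(CC)C(=O)CN(c1ccc(C)cc1)S(=O)(=O)c1ccc(OC)c(OC)c1`, compound 2 `CCN(CC)C(=O)CN(c1cc(N2CCCC2)ccc1Cl)S(=O)(=O)c1ccc(OC)c(OC)c1`, and compound 3 `CCN(CC)C(=O)CN(c1ccc(C)cc1)S(=O)(=O)c1ccc(OC)cc1`. In a functional assay on CHO cells for inhibition of Orexin/Hypocretin receptor type 1 (Homo sapiens), read by FLIPR and calcium flux (a higher number here means a weaker inhibitor, a lower number a stronger inhibitor), compound 3 gives > 10000 nM, which is a limit of the assay and not a number. Compound 1 likewise gives > 10000 nM, again a limit. Compound 2 gives 2530 nM. Among the measured compounds shown here, the only single-site step measured, a step that the two limits leave unreadable from compound 1 to compound 3, cannot be read because of the limit of > 10000 nM in this assay, at which 2 of the 3 values shown sit, so it tells nothing about the size of effects on the sulfonyl aryl group.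

Compound 4 `CCN(CC)C(=O)CN(c1ccc(C)cc1)S(=O)(=O)c1cccc(F)c1` has not yet been measured. It differs from compound 3 by 3-fluorophenyl in place of 4-methoxyphenyl on a sulfonyl sulfur. For the measured compounds named here, no measured step bears on this change; the one step involving the sulfonyl aryl group is unreadable. Given that compound 3 stands at the limit, compound 4 is expected to stay at or near that limit, with no movement readable beyond the scatter. The expected step is a step that the limit leaves unreadable from compound 3 to compound 4. Compound 4 is therefore estimated at 15000 nM, with a range from 4000 nM to 60000 nM.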

Compound 4, half-maximal inhibitory concentration: > 10000 nM
Compound 4: only a limit was reported; the forecaster's own chance of this, stated with the estimate: 70%; the middle value lies beyond the limit too.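

In this assay compound 4 gives > 10000 nM, which is a limit and not a number. The step between compound 3 and compound 4 cannot be read, because both stand at that limit: the limit of > 10000 nM in this assay, at which 3 of the 4 values shown sit. The compounds shown leave open how far any change of the sulfonyl aryl group moves inhibition.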